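Methyl tetrazole in place of the amide on compound 2

The source may report more compounds than this note shows. Statements on the series, on what has been measured and on what is new or still open speak of the compounds shown alone.

Measured so far:
Compound 2, `CC(C)(N)CC(=O)N[C@@H]1CCc2ccccc2N(Cc2ccc(-c3ccccc3C(N)=O)cc2)C1=O` — 0.08 uM
Compound 1, `CC(C)(N)CC(=O)N[C@@H]1CCc2ccccc2N(Cc2ccc(-c3ccccc3-c3nnnn3Cc3ccccc3)cc2)C1=O` — 0.7 uM

In a functional assay (Pituitary gland cell) with Rattus norvegicus as the target (a lower number here means that less compound is needed, a higher number that more compound is needed for the effect), compound 2 holds the lower of the two numbers, and compound 1 the higher. Compound 3, `Cn1nnc(-c2ccccc2-c2ccc(CN3C(=O)[C@H](NC(=O)CC(C)(C)N)CCc4ccccc43)cc2)n1`, differs from compound 2 by 2-methyl-2H-tetrazol-5-yl in place of carbamoyl on an aromatic carbon. Among the measured compounds shown here, the single step available, an 8.8-fold lower number from compound 1 to compound 2 (0.94 log units; beyond the scatter), moved in the opposite direction, though with a 1-benzyl rather than a 2-methyl tetrazole. A partial reversal of that step is therefore expected, a 3.8-fold higher number from compound 2 to compound 3 (0.57 log units; beyond the scatter), a modest rise in this assay. Compound 3 is estimated at 0.3 uM, within a range from 0.08 uM to 1 uM.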

Compound 3, concentration for half-maximal effect: 0.3 uM
For compound 3 middle estimate and measured number coincide at the digits printed, and the stated range covers the measured number.
By their numbers in this assay, from the lowest: compound 2; then compound 3; then compound 1.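

With a 3.8-fold higher number from compound 2 to compound 3 (0.57 log units; beyond the scatter) in this assay, a tetrazole carrying only a methyl group still falls short of carbamoyl on this aromatic carbon, so the benzyl group does not account for the whole gap seen earlier. The substituent on the tetrazole matters as well: a 2.3-fold lower number from compound 1 to compound 3 (0.37 log units; beyond the scatter) marks a partial recovery, in a step that changes both the group and the tetrazole nitrogen carrying it. No measurement here explains either step.

Still open, on these data alone, is how an unsubstituted tetrazole, a 1-methyl-1H-tetrazol-5-yl or a carboxylic acid would compare with carbamoyl at this place.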